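Sulfamoyl replacing the benzyltetrazole on the biaryl arm

The source may report more compounds than this note shows. Statements on the series, on what has been measured and on what is new or still open speak of the compounds shown alone.

The three measured compounds share one core and differ only in the substituent on the outer aromatic ring. In a functional assay (Pituitary gland cell) with Rattus norvegicus as the target (on this read-out lower numbers stand for an effect already at smaller amounts and higher numbers for an effect only at larger amounts of compound), compound 1 `CC(O)Cn1nnnc1-c1ccccc1-c1ccc(CN2C(=O)[C@H](NC(=O)CC(C)(C)N)CCc3ccccc32)cc1` gives 0.05 uM. Compound 2 `CC(C)(N)CC(=O)N[C@@H]1CCc2ccccc2N(Cc2ccc(-c3ccccc3-c3nnn(CC(=O)O)n3)cc2)C1=O` gives 0.2 uM in this assay, and compound 3 `CC(C)(N)CC(=O)N[C@@H]1CCc2ccccc2N(Cc2ccc(-c3ccccc3-c3nnnn3Cc3ccccc3)cc2)C1=O` gives 0.7 uM, the highest of the three numbers, with a 3.5-fold higher number from compound 2 to compound 3 (0.54 log units; beyond the scatter) and a 14-fold higher number from compound 1 to compound 3 (1.15 log units; beyond the scatter). Compound 4 `CC(C)(N)CC(=O)N[C@@H]1CCc2ccccc2N(Cc2ccc(-c3ccccc3S(N)(=O)=O)cc2)C1=O` carries sulfamoyl in place of 1-benzyl-1H-tetrazol-5-yl on an aromatic carbon. Among the measured compounds shown here, the steps that bear on this change are those at the same position: a 4.0-fold higher number from compound 1 to compound 2 (0.60 log units; beyond the scatter) and a 3.5-fold higher number from compound 2 to compound 3 (0.54 log units; beyond the scatter), each modest, and the larger 14-fold higher number from compound 1 to compound 3 (1.15 log units; beyond the scatter). They show that substituent changes at this site move the number by modest to large amounts, with compound 3 already at the weak end, so a shift back toward the numbers of compound 1 and compound 2 is expected rather than a further rise. Compound 4 is therefore estimated at 0.3 uM in this assay, within 0.06 uM to 1.5 uM, which means an expected step of a 2.3-fold lower number from compound 3 to compound 4 (0.37 log units; beyond the scatter).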

Compound 4, concentration for half-maximal effect: 3 uM
Estimate against measurement, compound 4: 10-fold (1.00 log units) below; the whole stated range lies below it.
By their numbers in this assay, from the lowest: compound 1; then compound 2; then compound 3; then compound 4.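

Sulfamoyl does not bring the number back toward the tetrazole-bearing compounds. In this assay the change gives a 4.3-fold higher number from compound 3 to compound 4 (0.63 log units; beyond the scatter), and the gaps to the other two widen to a 15-fold higher number from compound 2 to compound 4 (1.18 log units; beyond the scatter) and a 60-fold higher number from compound 1 to compound 4 (1.78 log units; beyond the scatter), so compound 3 no longer marks the weak end of this position and all three tetrazole-bearing compounds have lower numbers than compound 4. No supporting measurement here accounts for this rise.

On these data alone, it remains open whether a carboxylic acid or an amine placed directly on this aromatic carbon would fall nearer compound 1 or nearer compound 4. Also open, as far as these compounds go, is whether a methyl on the sulfamoyl nitrogen, or a longer chain joining the sulfamoyl to the ring, would shift the number from that of compound 4.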